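Hydroxy Added to Compound 3 in an Indoleamine Dioxygenase Series

This account rests on a few compounds, and the source may have more. Where it says the series, first, only, none or still open, it means among the compounds named here.

Compound 1, `N#Cc1ccc(NC(=O)NCc2cnc3scc(-c4ccc(Br)cc4)n23)cc1`: 97%
Compound 2, `COc1ccc(C(=O)N(C)CC(=O)NCc2cnc3scc(-c4ccc(Br)cc4)n23)cc1`: 49%
Compound 3, `N[C@H](C(=O)NCC(=O)NCc1cnc2scc(-c3ccc(Br)cc3)n12)c1ccccc1`: 10%

The three measured compounds share one core and differ in the chain attached to it. In an assay on isolated protein for inhibition of Indoleamine 2,3-dioxygenase 1 (Homo sapiens), with a stated time of 60 min, tested at 1 uM (a higher number here means more inhibition at the concentration tested (going by the name of the read-out), a lower number less inhibition), compound 1 gives 97%, compound 2 gives 49%, and compound 3 gives 10%, the lowest of the three: compound 2 stands well above it and compound 1 further still, both gaps beyond the scatter.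

Compound 4, `N[C@H](C(=O)NCC(=O)NCc1cnc2scc(-c3ccc(Br)cc3)n12)c1ccc(O)cc1`, has not yet been measured. It differs from compound 3 in one place: hydroxy in place of hydrogen on an aromatic carbon. Going by the values given here, no measured pair here shows how such a change plays out, so the step is expected to be small, a number 5 percentage points higher from compound 3 to compound 4 (within the scatter), with no direction beyond the scatter. Compound 4 is therefore estimated at 15%, within 0% to 45%.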

Compound 4, a percentage reported as inhibition, at one concentration (the size of the read-out at that concentration, not a potency): 0%
Compound 4: the middle estimate sits 15 percentage points above what was measured, and the stated range covers the measured number.
By their numbers in this assay, from the lowest: compounds 4 and 3 (each within the scatter of the next); then compound 2; then compound 1.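

In this assay, going by these compounds alone, this pair gives the first direct reading of the aromatic position, and the change from phenyl to 4-hydroxyphenyl gives a number 10 percentage points lower from compound 3 to compound 4 (within the scatter) with no effect beyond the scatter. Since compound 3 already starts low, this position had little room to show a loss, so a hydroxy here did not bring inhibition back. No measurement shown gives a reason for this step.

Going by these compounds, whether a methoxy, a fluorine or an amine on the same carbon would behave alike remains open. So does the effect of a hydroxy on a compound with higher inhibition.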